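Methoxy step on the aryloxy acid series, whole-animal dosing

The compounds below may be only part of what the source reports. "The series", "measured", "known", "first", "only" and "open" are said of these compounds alone.

Measured compounds:
compound 1 `CC(C)c1ccc(OC(C)(Cc2ccccc2)C(=O)O)cc1`: > 10 mg/kg (a limit)
compound 2 `COc1ccc(CC(C)(Oc2ccc(C(C)C)cc2)C(=O)O)cc1`: > 10 mg/kg (a limit)
compound 3 `CC(Cc1ccc(Cl)cc1)(Oc1ccc(Cc2ccccc2)cc1)C(=O)O`: 1 mg/kg

In a functional assay on the whole organism for inhibition, with Rattus norvegicus as the target (on this read-out lower numbers stand for an effect already at smaller amounts and higher numbers for an effect only at larger amounts of compound), compound 1 gives only > 10 mg/kg, which is a limit of the assay and not a number. Compound 2 likewise gives only > 10 mg/kg, again a limit. Going by the values given here, compound 3 gives 1 mg/kg, the only number in the set. The change methoxy in place of hydrogen on an aromatic carbon therefore made the step that the two limits leave unreadable from compound 1 to compound 2, unreadable because the limit of > 10 mg/kg in this assay, at which 2 of the 3 values shown sit, marks where both values sit. The difference between the core of compound 1 and the core of compound 3 is not broken down here.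

Compound 4 `COc1ccc(Cc2ccc(OC(C)(Cc3ccc(Cl)cc3)C(=O)O)cc2)cc1` carries the same change relative to compound 3, (methoxy in place of hydrogen on an aromatic carbon), at a place described in the same words as for the earlier pair. With the earlier step unreadable, nothing in the series supports either gain or loss, so compound 4 is expected to stay close to compound 3, an estimated step of a 1.3-fold higher number from compound 3 to compound 4 (0.11 log units; within the scatter) in this assay. Compound 4 is expected to give about 1.3 mg/kg, with the likely range from 0.4 mg/kg to 4 mg/kg.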

Compound 4, dose for half-maximal effect: < 10 mg/kg
Compound 4 ended at the assay's limit (the forecaster's own chance of this, stated with the estimate: 20%); the middle value is on the limit's open side.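

In this assay compound 4 gives < 10 mg/kg, which is a limit of the assay and not a number. No step can be read between compound 3 and compound 4, nor between compound 1 and compound 2. The compounds shown leave open how large the effect of methoxy in place of hydrogen is in either pair, and in which direction it runs.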